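Methyl on the benzyl group of compound 3

The compounds below may be only part of what the source reports. "The series", "measured", "known", "first", "only" and "open" are said of these compounds alone.

Compound 3 (`O=C(O)c1cn(Cc2ccccc2)c2ccc(Cc3cccc(Cl)c3F)c(O)c2c1=O`) gives 20300 nM in an ADME assay on C8166 cells (Homo sapiens) for cytotoxicity, read by MTT assay (a lower number here means that less compound is tolerated, a higher number that more compound is tolerated), and stands lowest of the three measured numbers. Compound 1 (`Cc1cccc(-n2cc(C(=O)O)c(=O)c3c(O)c(Cc4cccc(Cl)c4F)ccc32)c1`) stands at 71600 nM and compound 2 (`Cc1ccc(-n2cc(C(=O)O)c(=O)c3c(O)c(Cc4cccc(Cl)c4F)ccc32)cc1C`) at 316000 nM in the same read-out. Compound 4 (`Cc1ccc(Cn2cc(C(=O)O)c(=O)c3c(O)c(Cc4cccc(Cl)c4F)ccc32)cc1`) is unmeasured and differs from compound 3 by methyl in place of hydrogen on an aromatic carbon, para to a large group, so benzyl becomes 4-methylbenzyl. Going by the values given here, the one measured step of this kind (a 4.4-fold higher number from compound 1 to compound 2 (0.64 log units; beyond the scatter)) was modest and sat on a phenyl group, not a benzyl. The benzyl steps (a 3.5-fold lower number from compound 1 to compound 3 (0.55 log units; beyond the scatter) and a 16-fold lower number from compound 2 to compound 3 (1.19 log units; beyond the scatter)) are a different change and show only that this nitrogen substituent can move the number. A modest step toward a higher number is therefore expected in this assay (a 2.5-fold higher number from compound 3 to compound 4 (0.39 log units; beyond the scatter)) on this single precedent. Compound 4 is estimated at 50000 nM (expected range 15000 nM to 160000 nM).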

Compound 4, half-maximal cytotoxic concentration: 256000 nM
Beside the measured number, compound 4's estimate is 5.1-fold (0.71 log units) below it; the whole stated range lies below it.
By their numbers in this assay, from the lowest: compound 3; then compound 1; then compounds 4 and 2 (each within the scatter of the next).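

The low number of compound 3 belongs to unsubstituted benzyl, not to benzyl-type groups as a whole: 4-methylbenzyl gives a 13-fold higher number from compound 3 to compound 4 (1.10 log units; beyond the scatter). Against the aryl groups on the same nitrogen, 4-methylbenzyl gives a 1.2-fold lower number from compound 2 to compound 4 (0.09 log units; within the scatter) and a 3.6-fold higher number from compound 1 to compound 4 (0.55 log units; beyond the scatter), so a benzyl-type group here can match 3,4-dimethylphenyl. The size of the methyl step in this assay depends on the group that carries it: the same change on two cores in this assay, a 4.4-fold higher number (0.64 log units; beyond the scatter) from compound 1 to compound 2 and a 13-fold higher number (1.10 log units; beyond the scatter) from compound 3 to compound 4, 2.9-fold (0.46 log units) apart, beyond the scatter of two such steps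

Open, from the compounds shown here alone, is whether this step belongs to methyl itself or would also appear with chlorine, methoxy or an amine at this place. Also open, going by these compounds, is how a longer chain there would read.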